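Removing methoxymethyl from compound 2

The source may report more compounds than this note shows. Statements on the series, on what has been measured and on what is new or still open speak of the compounds shown alone.

Measured in an ADME assay on microsomes from liver (Homo sapiens) for metabolic stability; a higher number here means that the compound lasts longer, a lower number that the compound disappears faster:
Compound 1 `COC[C@H](NC(=O)[C@H](CSC)NC(=O)c1cc(Cl)ccc1Cl)C(=O)N[C@@H](CC(C)C)C(=O)[C@@]1(C)CO1`: < 0.0834 h (a limit of the assay)
Compound 2 `COC[C@H](NC(=O)[C@H](CSC)NC(=O)c1cc(C)on1)C(=O)N[C@@H](CC(C)C)C(=O)[C@@]1(C)CO1`: 0.382 h

For the measured compounds named here, compound 2 , at 0.382 h, holds the only actual number so far. Compound 1 rests on (the limit of < 0.0834 h in this assay, at which 1 of the 2 values shown sits). Compound 3 `CSC[C@H](NC(=O)c1cc(C)on1)C(=O)NCC(=O)N[C@@H](CC(C)C)C(=O)[C@@]1(C)CO1` differs from compound 2 by hydrogen in place of methoxymethyl on a saturated chain carbon bound to an amide-type nitrogen and a carbonyl carbon, with hydrogen in place of methoxymethyl on a saturated chain carbon bound to an amide-type nitrogen and a carbonyl carbon. Going by the values given here, the one measured step, an at least 4.5-fold higher number from compound 1 to compound 2 (0.66 log units; beyond the scatter), lies elsewhere in the molecule and bears on this change only indirectly. Among the compounds with values here, no step at this place has been measured, so no change beyond the scatter is expected in this assay, in either direction. The estimated step is a 1.2-fold lower number from compound 2 to compound 3 (0.06 log units; within the scatter). The half-life expected for compound 3 is 0.33 h, within an estimated range of 0.12 h to 0.9 h.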

Compound 3, half-life: 0.527 h
Beside the measured number, compound 3's estimate is 1.6-fold (0.20 log units) below it; low and high end bracket the measured number.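

In this assay, for the compounds shown here, replacing methoxymethyl with hydrogen gives the first measured step at this position: a 1.4-fold higher number from compound 2 to compound 3 (0.14 log units; within the scatter). Compound 2 and compound 3 thus stand within the scatter of each other, so the half-life of compound 2 does not depend on methoxymethyl on this saturated chain carbon. Nothing shown accounts for this result.

Going by these compounds, whether an amine, a hydroxymethyl or a longer chain on this carbon would give a step beyond the scatter remains open. So does whether hydrogen here would give a similar step with 2,5-dichlorophenyl on the carbonyl carbon.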